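Swapping a ring for an ether on the second amide

A few compounds are considered here, and "the series" means these few. Any claim that something is new, unique, unknown or untested is made for them only; others in the source may bear on it.

Of the compounds shown here, three sharing one core have been measured in a functional assay on WI-38 VA13 cells (Homo sapiens) for cytotoxicity; a lower number here means that less compound is needed, a higher number that more compound is needed for the effect. Compound 1 `O=C(Nc1ccc2nc(NC(=O)C3CCCCC3)sc2c1)c1ccccc1F` gives 0.14 ug/mL, and compound 2 `CC(C)COC(=O)Nc1ccc2nc(NC(=O)C3CCCCC3)sc2c1` gives 0.72 ug/mL. Compound 3 `O=C(Nc1ccc2nc(NC(=O)C3CCC3)sc2c1)c1c(Cl)cccc1Cl` gives 0.013 ug/mL, the lowest of the three numbers: compound 1 is nearest and compound 2 furthest, and both gaps lie beyond the scatter.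

Compound 4 `CC(C)OC(=O)Nc1nc2ccc(NC(=O)c3c(Cl)cccc3Cl)cc2s1` has not been measured yet. It differs from compound 3 in one place: isopropoxy in place of cyclobutyl on a carbonyl carbon. For the measured compounds named here, the only measured step of a related kind is a 5.1-fold higher number from compound 1 to compound 2 (0.71 log units; beyond the scatter), where an isobutoxy group on a carbonyl carbon took the place of an aromatic ring. That step sits on the other amide of the core, so it is only a loose guide, but it points toward a higher number when an alkoxy group replaces a carbon ring on a carbonyl carbon.

Compound 4 is therefore expected to show a step of a 3.1-fold higher number from compound 3 to compound 4 (0.49 log units; beyond the scatter) in this assay, a modest rise in the number. For compound 4 the estimated value is 0.04 ug/mL, with a likely range from 0.01 ug/mL to 0.15 ug/mL.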

Compound 4, half-maximal effective concentration: 0.0026 ug/mL
For compound 4 the middle estimate is 15-fold (1.19 log units) above the measured one; measured number below the stated range.
By their numbers in this assay, from the lowest: compound 4; then compound 3; then compound 1; then compound 2.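

At this carbonyl carbon, isopropoxy in place of cyclobutyl gives a 5.0-fold lower number from compound 3 to compound 4 (0.70 log units; beyond the scatter) in this assay, even though the heavy-atom count stays the same and the change only opens the ring and brings in an oxygen. This direction is opposite to that of a 5.1-fold higher number from compound 1 to compound 2 (0.71 log units; beyond the scatter), a step with different groups at a different carbonyl carbon of the core, so among these compounds an alkoxy group in place of a ring does not move the number the same way at both sites. No measurement shown here explains the drop or says whether losing the ring or gaining the oxygen matters more.

An isopropyl group, which has no oxygen, and a cyclobutoxy group, which keeps the ring and adds the oxygen, would help separate those two parts of the change. As far as these compounds go, it also remains open whether isopropoxy would lower the number to a similar extent if the aromatic group shared by compound 3 and compound 4 were replaced by the 2-fluorophenyl group of compound 1.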